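Allyl in place of phenyl on an aromatic nitrogen

A few compounds are considered here, and "the series" means these few. Any claim that something is new, unique, unknown or untested is made for them only; others in the source may bear on it.

Two compounds have been measured in a functional assay on the whole organism (strain albino) for inhibition, with Rattus norvegicus as the target, read by paw edema, with stated times of 30 min and 3 h, at a dose of 0.28 mmol/kg by the oral route; on this read-out higher numbers stand for more inhibition at the one dose given (going by the name of the read-out) and lower numbers for less inhibition:

compound 1, `COc1cc(-c2nnc(SCC(=O)Nc3ccc(/C(C)=N/O)cc3)n2-c2ccccc2)cc(OC)c1OC`, which gives 66%
compound 2, `COc1ccc(-c2nnc(SCC(=O)Nc3ccc(/C(C)=N/O)cc3)n2-c2ccccc2)cc1OC`, which gives 77%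

Compound 1 stands lowest of these two numbers. Its nearest neighbour is compound 2, and the change of hydrogen in place of methoxy on an aromatic carbon brings a number 11 percentage points higher from compound 1 to compound 2 (beyond the scatter) in this assay.

Compound 3, `C=CCn1c(SCC(=O)Nc2ccc(/C(C)=N/O)cc2)nnc1-c1cc(OC)c(OC)c(OC)c1`, is not yet measured. It differs from compound 1 at a different site: allyl in place of phenyl on an aromatic nitrogen. Within the data shown here, the one measured step concerns a substituent on an aromatic carbon of the 3,4,5-trimethoxyphenyl group and leaves the aromatic nitrogen untouched, so no measured step bears directly on this change. With nothing to point either way, a step of compound 3 away from compound 1 in this assay is expected to stay within the usual scatter, so the expected step is no change at the digits printed from compound 1 to compound 3 (within the scatter). Compound 3 is therefore estimated at 66% in this assay, with a range from 50% to 80%, the width reflecting that an untested site is changed.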

Compound 3, a percentage reported as inhibition, in the whole organism at one dose (the size of the read-out at that dose, not a potency): 62%
The estimate for compound 3 lay 4 percentage points above the measured number; the range from low to high includes it.
By their numbers in this assay, from the lowest: compounds 3 and 1 (each within the scatter of the next); then compound 2.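

Swapping phenyl for allyl on the aromatic nitrogen gives a number 4 percentage points lower from compound 1 to compound 3 (within the scatter) in this assay. Among these compounds, this is the first look at this position, and it shows that, with the 3,4,5-trimethoxyphenyl group in place, the read-out stays within the usual scatter when a six-membered aromatic ring of 6 heavy atoms gives way to an open chain of 3 heavy atoms with one double bond, so an aromatic ring on this nitrogen is not needed to keep inhibition at this one dose. Nothing available here explains why the two groups give such similar numbers.

The compounds shown leave open whether the same swap would hold on the core of compound 2, which carries one methoxy group fewer and has the higher number of the earlier pair. They also leave open how far this position can be varied beyond phenyl and allyl, for instance with a longer chain such as n-butyl, with a benzyl group, or with a chain ending in an amine.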